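The source may report more compounds than this note shows. Statements on the series, on what has been measured and on what is new or still open speak of the compounds shown alone.

Measured compounds:
Compound 1 `CC(C)c1onc(-c2c(Cl)cccc2Cl)c1COc1ccc(-c2nc3cc(C(=O)O)ccc3n2C)cc1` gives 4410 nM in an assay on HEK-293T cells for antagonist activity at vitamin D3 receptor (Homo sapiens), read by a luciferase reporter, with a stated time of 24 h; a lower number here means a stronger inhibitor, a higher number a weaker inhibitor.
Compound 2 `CCC(CC)n1c(-c2ccc(OCc3c(-c4c(Cl)cccc4Cl)noc3C(C)C)cc2)nc2ccc(C(=O)O)cc21` gives 5690 nM in this assay.
Compound 3 `CC(C)c1onc(-c2c(Cl)cccc2Cl)c1COc1ccc(-c2nc3ccc(C(=O)O)cc3n2C2CCC2)cc1` gives 1100 nM in this assay.

Compound 3 stands lowest of the three numbers in this assay: compound 1 sits above it, and compound 2 further above it, both gaps beyond the scatter. For the measured compounds named here, the one measured step that bears on the change to compound 4 is the one in which cyclobutyl replaced pentan-3-yl on the aromatic nitrogen, a 5.2-fold lower number from compound 2 to compound 3 (0.71 log units; beyond the scatter), where the smaller group on that nitrogen went with the lower number.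

Compound 4 `CC(C)c1onc(-c2c(Cl)cccc2Cl)c1COc1ccc(-c2nc3ccc(C(=O)O)cc3n2C)cc1` differs from compound 3 by methyl in place of cyclobutyl on an aromatic nitrogen. The measured step runs from one larger group to a smaller one, so it does not say directly what a group as small as methyl will do. Compound 1 also carries methyl on the aromatic nitrogen, though its carboxylic acid sits elsewhere on the shared core, and it gives 4410 nM. On that basis compound 4 is expected to give a higher number than compound 3, a 2.7-fold higher number from compound 3 to compound 4 (0.44 log units; beyond the scatter), a step of modest size. The estimate for compound 4 in this assay is 3000 nM, with a range from 900 nM to 10000 nM.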

Compound 4, half-maximal inhibitory concentration: 7150 nM
Compound 4: the middle estimate sits 2.4-fold (0.38 log units) below what was measured; the measured number falls inside the stated range.
By their numbers in this assay, from the lowest: compound 3; then compounds 1, 2 and 4 (each within the scatter of the next).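

With a 6.5-fold higher number from compound 3 to compound 4 (0.81 log units; beyond the scatter) in this assay, methyl in place of cyclobutyl on the aromatic nitrogen shows that the earlier link between a smaller group and a lower number does not extend to methyl. Methyl and pentan-3-yl, the groups with the fewest and the most heavy atoms of the three at this position, are not separated, with a 1.3-fold higher number from compound 2 to compound 4 (0.10 log units; within the scatter). Among these three compounds, the number therefore does not follow the heavy-atom count in one direction, and only cyclobutyl stands apart.

From the compounds shown here alone, whether cyclopropyl, cyclopentyl or a straight propyl chain on this nitrogen would also give a number near that of cyclobutyl remains open. The data shown offer no independent measurement that accounts for this dependence on the group at this position.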